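This account rests on a few compounds, and the source may have more. Where it says the series, first, only, none or still open, it means among the compounds named here.

Measured in an ADME assay on cells (Astrocyte, Homo sapiens) for cytotoxicity, read by WST assay, with a stated time of 72 h; on this read-out lower numbers stand for stronger inhibition and higher numbers for weaker inhibition:
- Compound 1 `O=C(Nc1ccc(C(F)(F)F)cc1)Nc1cc2ncncc2cc1OCc1cccc(F)c1`: 8900 nM
- Compound 2 `O=C(Nc1ccc(Cl)c(Cl)c1)Nc1cc2ncncc2cc1OCc1cccc(F)c1`: 7400 nM

On these two numbers, compound 1 cannot be told apart from compound 2. The step between them is a 1.2-fold lower number from compound 1 to compound 2 (0.08 log units; within the scatter). Compound 3 `O=C(Nc1ccc(C(F)(F)F)cc1)Nc1cc2ncncc2cc1OCc1cccc(Cl)c1` keeps the core of compound 1 and differs in one place: chloro in place of fluoro on an aromatic carbon. This is chloro in place of fluoro on an aromatic carbon, meta to a large group, so 3-fluorobenzyl becomes 3-chlorobenzyl. Among the measured compounds shown here, no measured step covers this change. The only one available, 3,4-dichlorophenyl in place of 4-(trifluoromethyl)phenyl on an amide-type nitrogen, sits elsewhere and bears on it only indirectly, as a sign that a halogen exchange on this scaffold can leave this assay unmoved. No shift beyond the scatter is therefore expected, in either direction. The estimated step is a 1.1-fold lower number from compound 1 to compound 3 (0.05 log units; within the scatter). Compound 3 is expected at 8000 nM, with an estimated range of 4000 nM to 16000 nM.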

Compound 3, half-maximal inhibitory concentration: 8800 nM
Compound 3: middle estimate off by 1.1-fold (0.04 log units), on the low side, within the range that was stated.
By their numbers in this assay, from the lowest: compounds 2, 3 and 1 (each within the scatter of the next).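

Chloro in place of fluoro on an aromatic carbon gives in this assay a step of a 1.0-fold lower number from compound 1 to compound 3 (0.00 log units; within the scatter) so 3-fluorobenzyl and 3-chlorobenzyl cannot be told apart in this read-out. The earlier step concerned only the aryl group on an amide-type nitrogen, whereas this one reads the (3-fluorobenzyl)oxy part of compound 1 directly and shows that this single halogen exchange there leaves the number within the scatter. No experimental evidence is available to explain this result.

The compounds shown leave open whether any halogen matters on this ring, since a methoxy group, an amine or a carboxylic acid in that place could read differently. They also leave open whether the benzyl group itself could give way to a longer chain without a shift in this assay as well.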